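Kinetic solubility after swapping the aryl group of compound 1

A few compounds are considered here, and "the series" means these few. Any claim that something is new, unique, unknown or untested is made for them only; others in the source may bear on it.

Compound 1 `Cc1oc(-c2ccccc2Cl)nc1CN1CCC(C(=O)NCCCN2C[C@H](C)C[C@H](C)C2)CC1`: > 72 ug/mL
Compound 2 `Cc1ccccc1-c1nc(CN2CCC(C(=O)N3CCN(CCN(C)C)CC3)CC2)c(C)o1`: > 67 ug/mL

Both compounds were measured in a physicochemical assay for solubility, in phosphate buffer, measured as kinetic solubility, at pH 7.4; a lower number here means a less soluble compound, a higher number a more soluble compound. Compound 1 gives > 72 ug/mL, which is a limit of the assay and not a number. Compound 2 gives > 67 ug/mL, which is also a limit.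

Compound 3 `Cc1cccc(F)c1-c1nc(CN2CCC(C(=O)NCCCN3C[C@H](C)C[C@H](C)C3)CC2)c(C)o1` keeps the rest of compound 1 and changes one group. It carries 2-fluoro-6-methylphenyl in place of 2-chlorophenyl on an aromatic carbon. Neither group carries a net charge.

Going by the values given here, no two measured compounds differ in just one place, so the data offer no direct guide to the size of this step. The expectation therefore rests on compound 1 and its limit of > 72 ug/mL. In this assay, no step beyond the usual scatter is expected, and neither direction is favoured. The estimated step is an at least 1.0-fold lower number from compound 1 to compound 3 (0.02 log units; that floor lies within the scatter). For compound 3 the expected value is 68 ug/mL, with an estimated range from 35 ug/mL to 75 ug/mL.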

Compound 3, solubility: > 72 ug/mL
Compound 3 ended at the assay's limit; the forecaster's own chance of this, stated with the estimate: 75%; at least 1.0-fold (0.02 log units) between middle value and limit.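

In this assay compound 3 gives > 72 ug/mL, which is a limit of the assay. Compound 1 also sits at a limit, and no step can be read between compound 1 and compound 3. The compounds shown leave open where the true solubility of each lies, and whether 2-fluoro-6-methylphenyl in place of 2-chlorophenyl changes it at all.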